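The compounds below may be only part of what the source reports. "The series", "measured", "known", "first", "only" and "open" are said of these compounds alone.

Measured so far:
Compound 1, `CCCCCCCCC[C@]1(CO)NC[C@@H](O)[C@@H]1O`: 130000 nM
Compound 2, `OC[C@@]1(c2ccc(O)cc2)NC[C@@H](O)[C@@H]1O`: 372000 nM
Compound 3, `CCCC[C@@]1(CO)NC[C@H](O)[C@H]1O`: 2400 nM

All three compounds were tested in an assay on isolated protein for inhibition of lysosomal alpha-glucosidase (Homo sapiens); on this read-out lower numbers stand for stronger inhibition and higher numbers for weaker inhibition. Among these three numbers compound 3 stands lowest, and its distance to compound 1 and to compound 2 lies beyond the usual scatter, so it is the strongest inhibitor of the set. Going by the values given here, compound 1 and compound 2 give much higher numbers, but they also differ from compound 3 in more than one place, so no single step between measured compounds can be read off here.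

Compound 4, `C[C@@]1(CO)NC[C@H](O)[C@H]1O`, is not yet measured. It is drawn from compound 3 by one change: hydrogen in place of propyl on a saturated chain carbon bound to a saturated ring carbon. Among the compounds with values here, no measured pair shows what such a shortening of the chain does in this assay, so the size of the step can only be guessed. A moderate weakening is expected, the step from compound 3 to compound 4 being estimated at a 3.3-fold higher number from compound 3 to compound 4 (0.52 log units; beyond the scatter). Compound 4 is therefore expected to give about 8000 nM, within a range from 2000 nM to 40000 nM.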

Compound 4, half-maximal inhibitory concentration: 5600 nM
Compound 4: the middle estimate sits 1.4-fold (0.15 log units) above what was measured; the measured number falls inside the stated range.
By their numbers in this assay, from the lowest: compound 3; then compound 4; then compound 1; then compound 2.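

Going from butyl to methyl on the shared core of compound 3 gives the first direct reading of this position in this assay: the change, hydrogen in place of propyl on a saturated chain carbon bound to a saturated ring carbon, produces a 2.3-fold higher number from compound 3 to compound 4 (0.37 log units; beyond the scatter). This step is modest, though beyond the usual scatter, and compound 4 keeps a measurable inhibition at 5600 nM, so on this core most of the chain can go at a small loss. No measured property of these compounds accounts for the step.

Compound 1 and compound 2 differ from this pair in more than one place, so they add nothing about this position. As far as these compounds go, how an ethyl chain, or an amine or a carboxylic acid at the end of the chain, would behave here remains open.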